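The source may hold more compounds than are shown below. What is called first, only, known or untested is meant among the compounds shown, and "the series" means these compounds.

Measured so far:
compound 1, `CCCCOC(=O)Cc1c(C(C)C)nc(CCCC)n(Cc2ccc(-c3ccccc3-c3noc(=O)[nH]3)cc2)c1=O`: 7.1%
compound 2, `CCCCOC(=O)Cc1c(C)nc(CCCC)n(Cc2ccc(-c3ccccc3-c3noc(=O)[nH]3)cc2)c1=O`: 2.8%

Both numbers come from an ADME assay on microsomes from liver (Homo sapiens) for metabolic stability, with a stated time of 30 min; on this read-out lower numbers stand for a less stable compound and higher numbers for a more stable compound. Compound 2 gives the lower of the two numbers, but the gap to compound 1, a number 4.3 percentage points lower from compound 1 to compound 2 (within the scatter), is within the scatter, so the two values cannot be told apart. Going by the values given here, that step, methyl in place of isopropyl on an aromatic carbon, is the only measured comparison available.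

Compound 3, `CCCCc1nc(C)c(CC(=O)OCC2CCCCC2)c(=O)n1Cc1ccc(-c2ccccc2-c2noc(=O)[nH]2)cc1`, has not yet been measured in this assay. It differs from compound 2 at another place: cyclohexyl in place of propyl on a saturated chain carbon bound to an oxygen next to a carbonyl group. Among the compounds with values here, no measured step touches the saturated chain carbon bound to an oxygen next to a carbonyl group, so nothing among the measured compounds shows directly what this change does. Within the data shown here, the only guide is that both measured compounds give low numbers and the single measured step stayed within the scatter.

Compound 3 is therefore expected to stay low, with an expected step of a number 2.2 percentage points higher from compound 2 to compound 3 (within the scatter), no larger than the scatter. The estimate for compound 3 is 5%, expected to fall between 1% and 20%.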

Compound 3, percent of the compound remaining: 11.5%
For compound 3 the middle estimate is 6.5 percentage points below the measured one; the range from low to high includes it.
By their numbers in this assay, from the lowest: compounds 2, 1 and 3 (each within the scatter of the next).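

Going by these compounds alone, this is the first measured comparison at this position. In this assay, cyclohexyl in place of propyl on a saturated chain carbon bound to an oxygen next to a carbonyl group gives a number 8.7 percentage points higher from compound 2 to compound 3 (within the scatter), so butoxycarbonyl and cyclohexylmethoxycarbonyl cannot be told apart on this read-out, even though the entering group brings a six-membered non-aromatic ring and more heavy atoms than the propyl it replaces. Together with a number 4.3 percentage points lower from compound 1 to compound 2 (within the scatter), this means that neither of the two changes, each made at a different place on the molecule, gives a step beyond the scatter. Nothing available explains the size of either step.

Still open, as far as these compounds go, is whether any group at this position can give a step beyond the scatter, for example a longer chain, a chain ending in an amine, or a carboxylic acid in place of the butoxycarbonyl group. Within the data shown here, also open is whether cyclohexylmethoxycarbonyl would behave the same way with isopropyl in place of the methyl on the aromatic carbon, since no pair here tests the two changes together.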